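Trading a Sulfanyl Arm for a Pentyl Chain

This account rests on a few compounds, and the source may have more. Where it says the series, first, only, none or still open, it means among the compounds named here.

Three compounds share one core and differ only in the group on one aromatic carbon. Compound 1 `CCCCOc1nc(C(C)(C)C)ccc1CNC(=O)C(C)c1ccc(NS(C)(=O)=O)c(F)c1` carries butoxy there and gives 0.9 nM in an assay on cells for antagonist activity at transient receptor potential cation channel subfamily V member 1 (Homo sapiens), read by FLIPR and calcium flux, with a stated time of 6 min; on this read-out lower numbers stand for stronger inhibition and higher numbers for weaker inhibition. Compound 2 `CC(C(=O)NCc1ccc(C(C)(C)C)nc1SCc1ccccc1)c1ccc(NS(C)(=O)=O)c(F)c1` gives 4 nM, and compound 3 `CC(C(=O)NCc1ccc(C(C)(C)C)nc1SCc1ccccc1Cl)c1ccc(NS(C)(=O)=O)c(F)c1` gives 3.8 nM. Compound 3 thus stands second highest of the three numbers, nearest to compound 2, as a 1.1-fold lower number from compound 2 to compound 3 (0.02 log units; within the scatter) shows, and farthest from compound 1, as a 4.2-fold higher number from compound 1 to compound 3 (0.63 log units; beyond the scatter) shows.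

Compound 4 `CCCCCc1nc(C(C)(C)C)ccc1CNC(=O)C(C)c1ccc(NS(C)(=O)=O)c(F)c1` has not yet been measured; it differs from compound 3 in that (pentyl in place of (2-chlorobenzyl)sulfanyl on an aromatic carbon). For the measured compounds named here, no measured step exchanges the sulfanyl arm for a plain chain directly. Going by the values given here, the steps that bear on it are a 4.4-fold higher number from compound 1 to compound 2 (0.65 log units; beyond the scatter) and a 4.2-fold higher number from compound 1 to compound 3 (0.63 log units; beyond the scatter), both leaving a butoxy chain for a benzylsulfanyl group, while a 1.1-fold lower number from compound 2 to compound 3 (0.02 log units; within the scatter) adds nothing beyond the scatter. Pentyl is a chain, as the butoxy of compound 1 is, and compound 4 is expected to move part of the way back toward compound 1 because compound 1 gives 0.9 nM, with an estimated step of a 2.4-fold lower number from compound 3 to compound 4 (0.38 log units; beyond the scatter). Compound 4 is therefore estimated at 1.6 nM, with a range from 0.5 nM to 5 nM.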

Compound 4, inhibition constant: 1.9 nM
Compound 4: middle estimate off by 1.2-fold (0.07 log units), on the low side; measured number inside the range.
By their numbers in this assay, from the lowest: compound 1; then compounds 4, 3 and 2 (each within the scatter of the next, the first and the last beyond it).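

In this assay, a chain on this aromatic carbon does not by itself recover the number of compound 1, since pentyl in place of butoxy gives a 2.1-fold higher number from compound 1 to compound 4 (0.32 log units; beyond the scatter). Pentyl, which has no ring and no sulfur, gives a 2.1-fold lower number from compound 2 to compound 4 (0.32 log units; beyond the scatter) against benzylsulfanyl and a 2.0-fold lower number from compound 3 to compound 4 (0.30 log units; within the scatter) against (2-chlorobenzyl)sulfanyl, the latter within the scatter, so neither the ring nor the sulfur of the arm is required for a number of this size. Nothing shown here accounts for these differences.

The compounds shown leave open how a hexyl chain, a benzyloxy group or a butylamino group on this carbon would compare with butoxy. They also leave open whether the gap between butoxy and pentyl would persist on a different core.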